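Moving the methyl on the phenyl of a pyridinyl ether

The compounds below may be only part of what the source reports. "The series", "measured", "known", "first", "only" and "open" are said of these compounds alone.

Of the compounds shown here, three sharing one core have been measured in an assay on membranes from brain for binding affinity to Neuronal acetylcholine receptor; alpha4/beta2 (Rattus norvegicus); on this read-out lower numbers stand for stronger inhibition and higher numbers for weaker inhibition. Compound 1 `Cc1ccccc1-c1cncc(OC[C@@H]2CCCN2C)c1` gives 1.1 nM, compound 2 `CN1CCC[C@H]1COc1cncc(-c2ccccc2C=O)c1` gives 0.56 nM, and compound 3 `CN1CCC[C@H]1COc1cncc(-c2cccc([N+](=O)[O-])c2)c1` gives 0.465 nM. Among these three numbers compound 1 stands highest; its nearest neighbour is compound 2, and its furthest is compound 3. Going by the values given here, the only single-point step within the set, a 2.0-fold lower number from compound 1 to compound 2 (0.29 log units; within the scatter), concerns a formyl in place of a methyl and says nothing about where the methyl sits.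

Compound 4 `Cc1ccc(-c2cncc(OC[C@@H]3CCCN3C)c2)cc1` is built from the same atoms as compound 1, joined differently: 4-methylphenyl in place of 2-methylphenyl on an aromatic carbon. Among the compounds with values here, no measured step bears directly on this change, since no pair of the measured compounds differs only in the position of a substituent on that phenyl. The relevant comparison is therefore compound 1 itself, whose value in this assay is 1.1 nM, with no guidance on the direction the change might take. In the absence of such guidance, compound 4 is expected to land near compound 1, with a step of a 1.4-fold higher number from compound 1 to compound 4 (0.13 log units; within the scatter) that should not exceed the usual scatter. The estimate for compound 4 in this assay is 1.5 nM, within a range from 0.5 nM to 5 nM.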

Compound 4, inhibition constant: 0.13 nM
The estimate for compound 4 lay 12-fold (1.06 log units) above the measured number; measured number outside the range, below it.
By their numbers in this assay, from the lowest: compound 4; then compounds 3, 2 and 1 (each within the scatter of the next, the first and the last beyond it).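

In this assay, moving the methyl around the phenyl gives an 8.5-fold lower number from compound 1 to compound 4 (0.93 log units; beyond the scatter), so at this position the place of the substituent on the phenyl matters, and not only which substituent is present. Going by these compounds alone, the earlier compounds could not show this, as their one step, a 2.0-fold lower number from compound 1 to compound 2 (0.29 log units; within the scatter), changes the group and leaves its place unchanged, and lies within the scatter. Here 2-methylphenyl and 4-methylphenyl match in heavy atoms, ring, hydrogen-bond donors, hydrogen-bond acceptors and charge, so these counts do not separate the two compounds, and nothing available explains why the change in connection shifts the number this far.

The compounds shown hold the methyl in only these two places, so any other placement on that phenyl remains open, as does whether the formyl of compound 2 would respond to the same move. From the compounds shown here alone, it is equally open whether a methoxy group, an amine or a longer chain such as propyl, set where the methyl sits in compound 4, would keep a number like that of compound 4.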